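The source may hold more compounds than are shown below. What is called first, only, known or untested is meant among the compounds shown, and "the series" means these compounds.

Working notes on the series.

Compound 1 `Cc1cccc(C)c1-c1c(N)c(C(=O)c2ccc(F)cc2F)cc[n+]1[O-]` gives 70 ug/mL in a physicochemical assay for solubility, at pH 9.0; a higher number here means a more soluble compound, a lower number a less soluble compound. Two further compounds carry a substituted phenyl ring on the same carbon of the shared core: compound 2 `COCCNC(=O)c1ccc(-c2c(N)c(C(=O)c3ccc(F)cc3F)cc[n+]2[O-])c(C)c1` gives 49 ug/mL in this assay, and compound 3 `COCCOc1ccc(-c2c(N)c(C(=O)c3ccc(F)cc3F)cc[n+]2[O-])c(C)c1` gives 89 ug/mL. Compound 1 sits among these two numbers, within the scatter of each of them. Among the measured compounds shown here, the only single-point step measured so far is a 1.8-fold higher number from compound 2 to compound 3 (0.26 log units; within the scatter), and it concerns the group on the pendant phenyl ring, not the ring itself.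

Compound 4 `Nc1c(C(=O)c2ccc(F)cc2F)cc[n+]([O-])c1-c1c(F)cccc1F` is derived from compound 1 by 2,6-difluorophenyl in place of 2,6-dimethylphenyl on an aromatic carbon. For the measured compounds named here, no measured step in the set covers an exchange of this kind; the step from compound 2 to compound 3 changes a different part of the molecule and cannot be carried over. With the three measured numbers lying within the scatter of one another, the expectation for this assay is a step of no change at the digits printed from compound 1 to compound 4 (within the scatter), that is, nothing beyond the scatter. Compound 4 is therefore estimated at 70 ug/mL, with a range of 35 ug/mL to 140 ug/mL.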

Compound 4, solubility: 2 ug/mL
Compound 4: middle estimate off by 35-fold (1.54 log units), on the high side; the whole stated range lies above it.
By their numbers in this assay, from the lowest: compound 4; then compounds 2, 1 and 3 (each within the scatter of the next).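

In this assay the exchange of 2,6-dimethylphenyl for 2,6-difluorophenyl on this aromatic carbon, next to the ring nitrogen, gives a 35-fold lower number from compound 1 to compound 4 (1.54 log units; beyond the scatter) and is a large step, so the group at this position can move the read-out well beyond the scatter. The numbers of compounds 1, 2 and 3 lay within the scatter of one another and gave no sign of such a step, and the counted features of the two groups show no difference in heavy atoms, hydrogen-bond donors, hydrogen-bond acceptors or net charge, with two fluorine atoms standing in the place of two carbon atoms. Nothing in the data shown bears on the reason for this step.

The compounds shown leave open whether the step needs both fluorine atoms, since a phenyl ring carrying one fluorine and one methyl, or two chlorine atoms, in the same places would separate the two substituents. They also leave open whether a 2-methoxyethoxy chain or a basic amine on the 2,6-difluorophenyl ring would bring the number back towards that of compound 1.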